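The source may report more compounds than this note shows. Statements on the series, on what has been measured and on what is new or still open speak of the compounds shown alone.

In a functional assay on HCT-116 cells (Homo sapiens) for antiproliferative activity, read by MTT assay, with a stated time of 24 h (on this read-out lower numbers stand for stronger inhibition and higher numbers for weaker inhibition), three compounds sharing one core have been measured. Compound 1 `COc1ccc(-c2noc(-c3ccccc3)n2)cc1OC1CCCC1`, which carries a phenyl, gives > 1000000 nM, and this is a limit of the assay, not a number. Compound 2 `COc1ccc(-c2noc(-c3ccncc3)n2)cc1OC1CCCC1`, with pyridin-4-yl in place of phenyl, gives > 1000000 nM, again a limit. Between these two the data show a step that the two limits leave unreadable from compound 1 to compound 2. Much of the picture therefore rests on (the limit of > 1000000 nM in this assay, at which 2 of the 3 values shown sit). For the measured compounds named here, compound 3 `COc1ccc(-c2noc(-c3ccc(O)cc3)n2)cc1OC1CCCC1` gives 270 nM, the only true number so far.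

Two measured steps lead to compound 3, and both are large. Hydroxy in place of hydrogen on an aromatic carbon gave an at least 3700-fold lower number from compound 1 to compound 3 (3.56 log units; beyond the scatter), while 4-hydroxyphenyl in place of pyridin-4-yl gave an at least 3700-fold lower number from compound 2 to compound 3 (3.56 log units; beyond the scatter).

Compound 4 `COc1ccc(-c2noc(-c3ccc(Cl)cc3)n2)cc1OC1CCCC1` has chloro in place of hydroxy on an aromatic carbon, para to a large group (chloro in place of hydroxy on an aromatic carbon). It gives up the hydroxy whose arrival came with an at least 3700-fold lower number from compound 1 to compound 3 (3.56 log units; beyond the scatter), so a move toward weaker inhibition is expected. Going by the values given here, no measured compound carries chloro, which leaves the size of that move uncertain, and compound 4 may also reach the limit. The estimate amounts to an expected step of a 74-fold higher number from compound 3 to compound 4 (1.87 log units; beyond the scatter). For compound 4, the expected value is 20000 nM, with an estimated range from 500 nM to 1000000 nM.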

Compound 4, half-maximal inhibitory concentration: > 1000000 nM
Compound 4: no number, only a limit; the forecaster's own chance of this, stated with the estimate: 35%; middle value at least 50-fold (1.69 log units) away from the limit.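

The earlier compounds shown here showed that adding a hydroxy to this ring helps, but not whether another small group could do the same job. Chloro answers this for one group: at this place on the aromatic ring, para to a large group, swapping hydroxy for chloro gives an at least 3700-fold higher number from compound 3 to compound 4 (3.56 log units; beyond the scatter) in this assay. Among the four compounds, a true number therefore appears only with hydroxy at this place, while the steps among compound 1, compound 2 and compound 4 cannot be read, because all three sit at the same limit rather than at numbers: the limit of > 1000000 nM in this assay, at which 3 of the 4 values shown sit.

What remains open is how specific this requirement for hydroxy is, since chloro is the only replacement shown and it differs from hydroxy in both its atom and its hydrogen-bond count. A methoxy, an amine, a fluoro or a carboxylic acid at the same place would show whether activity needs the hydroxy itself, and whether any other group can bring the value back from the limit to a true number.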